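The source may report more compounds than this note shows. Statements on the series, on what has been measured and on what is new or still open speak of the compounds shown alone.

Measured compounds:
compound 1 `CCCCS(=O)(=O)Nc1cc(-c2ccc3ncnc(NCCN(C)C)c3c2)cnc1OC`, 280 nM in a functional assay on MDA-MB-231 cells (Homo sapiens) for antiproliferative activity, read by sulforhodamine B assay, with a stated time of 72 h; a lower number here means a stronger inhibitor, a higher number a weaker inhibitor
compound 2 `COc1ncc(-c2ccc3ncnc(NCCN(C)C)c3c2)cc1NS(C)(=O)=O`, 2320 nM in this assay

For the measured compounds named here, compound 1 has the lowest number of the two measured in this assay; its nearest neighbour is compound 2, and the one step that separates them, hydrogen in place of propyl on the chain carbon bound to the sulfonyl sulfur, gives an 8.3-fold higher number from compound 1 to compound 2 (0.92 log units; beyond the scatter).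

Compound 3 `CCCCS(=O)(=O)Nc1cc(-c2ccc3ncnc(NCCCN(C)C)c3c2)cnc1OC` is not yet measured. It keeps the sulfonamide side of compound 1 unchanged and alters only the other end: (dimethylamino)methyl in place of dimethylamino on a saturated chain carbon, two bonds along the chain from a nitrogen on an aromatic ring. Read one bond further out, the 2-(dimethylamino)ethyl chain becomes 3-(dimethylamino)propyl.

Going by the values given here, no measured step concerns this chain; the single known step, from compound 1 to compound 2, touches a different part of the molecule, so it says little about what lengthening the amine chain does. With nothing to point either way, the expected step of a 1.1-fold higher number from compound 1 to compound 3 (0.03 log units; within the scatter) is none beyond the scatter. Compound 3 is therefore estimated at 300 nM in this assay, within a range of 110 nM to 900 nM.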

Compound 3, half-maximal inhibitory concentration: 880 nM
Compound 3: middle estimate off by 2.9-fold (0.47 log units), on the low side, and the stated range covers the measured number.
By their numbers in this assay, from the lowest: compound 1; then compound 3; then compound 2.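

The amine chain turns out not to be a neutral part of the molecule: in this assay, adding one carbon to turn the 2-(dimethylamino)ethyl chain into 3-(dimethylamino)propyl gives a 3.1-fold higher number from compound 1 to compound 3 (0.50 log units; beyond the scatter). For the compounds shown here, until now, only the sulfonyl end had been seen to move the number, so this is the first sign that both ends of the molecule matter to the antiproliferative effect, and that the shorter of the two chains goes with the lower number when the butylsulfonyl group stays in place. Nothing available explains why one extra carbon in this chain raises the number.

As far as these compounds go, two chain lengths give a single comparison and no trend, so it remains open whether a still longer 4-(dimethylamino)butyl chain would raise the number further, or whether a ring amine such as morpholine or pyrrolidine in place of dimethylamino would keep the number of compound 1. From the compounds shown here alone, it is also open whether the chain change would have a similar effect alongside the methylsulfonyl group of compound 2, since the two ends have so far been changed only one at a time.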